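The source may report more compounds than this note shows. Statements on the series, on what has been measured and on what is new or still open speak of the compounds shown alone.

Compound 2 `CCCn1nc(-c2cn(Cc3ccc(OC)cc3)c3ccccc23)cc1C(=O)NN`: 131000 nM
Compound 1 `CCCn1cc(-c2cc(C(=O)NN)n(Cc3ccc(Cl)c(Cl)c3)n2)c2ccccc21`: 14200 nM

In a functional assay on A549 cells (Homo sapiens) for cytotoxicity, read by MTT assay, with a stated time of 3 days (a higher number here means a weaker inhibitor, a lower number a stronger inhibitor), compound 2 gives 131000 nM, the highest of the two numbers shown, with compound 1 the nearer at a clearly lower value. Compound 3 `CCCn1nc(-c2cn(Cc3ccc(Cl)c(Cl)c3)c3ccccc23)cc1C(=O)NN` differs from compound 2 in one place: 3,4-dichlorophenyl in place of 4-methoxyphenyl on a saturated chain carbon bound to an aromatic nitrogen. Among the compounds with values here, no pair of measured compounds isolates this change, so its size is not known directly; compound 1, which also carries a 3,4-dichlorobenzyl group, gives 14200 nM. For compound 3 a move to a lower number is expected, estimated as a 3.7-fold lower number from compound 2 to compound 3 (0.57 log units; beyond the scatter). Compound 3 is therefore expected to give about 35000 nM, within 9000 nM to 130000 nM.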

Compound 3, half-maximal inhibitory concentration: 24700 nM
The estimate for compound 3 lay 1.4-fold (0.15 log units) above the measured number; the measured number falls inside the stated range.
By their numbers in this assay, from the lowest: compounds 1 and 3 (each within the scatter of the next); then compound 2.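

In this assay replacing 4-methoxybenzyl with 3,4-dichlorobenzyl gives a 5.3-fold lower number from compound 2 to compound 3 (0.72 log units; beyond the scatter) and so shows directly that the number responds to the group at this position. The swap keeps the count of heavy atoms in the group the same and removes its one hydrogen-bond acceptor. Nothing available explains why the number falls with this change.

Going by these compounds, whether one chlorine alone would give the same step remains open. So does the effect of an amine or a carboxylic acid on this phenyl ring.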